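The source may hold more compounds than are shown below. What is called first, only, known or untested is meant among the compounds shown, and "the series" means these compounds.

- compound 1 `CC(C)CNC(=N)NC(=N)Nc1ccc(F)c(F)c1` gives 2400 nM
- compound 2 `CCN(CC)C(=N)NC(=N)Nc1ccc(F)c(F)c1` gives 7800 nM
- compound 3 `CCCCCCCNC(=N)NC(=N)Nc1ccc(F)c(F)c1` gives 1500 nM

All three numbers come from a functional assay on A549 cells (Homo sapiens) for antiproliferative activity, read by MTT assay, with a stated time of 72 h (a higher number here means a weaker inhibitor, a lower number a stronger inhibitor), and the three compounds share one core. Compound 3 at 1500 nM cannot be separated from compound 1 (a 1.6-fold lower number from compound 1 to compound 3 (0.20 log units; within the scatter)) and compound 2 at 7800 nM has a higher number than either of them.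

Compound 4 `N=C(NC(=N)NC1CCCC1)Nc1ccc(F)c(F)c1` carries cyclopentyl in place of heptyl on an amine nitrogen. Among the measured compounds shown here, two measured steps bear on this change. The closer one swaps one simple carbon group for another, hexyl in place of isopropyl, and it stays within the scatter (a 1.6-fold lower number from compound 1 to compound 3 (0.20 log units; within the scatter)). The other, diethylamino in place of isobutylamino, is modest (a 3.3-fold higher number from compound 1 to compound 2 (0.51 log units; beyond the scatter)) but alters the nitrogen in a different way, so it guides less here. For the measured compounds named here, no measured compound has a ring on that nitrogen, which leaves the estimate uncertain.

In this assay a small move toward a higher number is therefore expected, landing near compound 1 rather than near compound 2. The estimated change is a 1.7-fold higher number from compound 3 to compound 4 (0.22 log units; within the scatter) in this measure. For compound 4 the expected value is 2500 nM with an estimated range from 1200 nM to 5500 nM as the likely span.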

Compound 4, half-maximal inhibitory concentration: 3500 nM
The estimate for compound 4 lay 1.4-fold (0.15 log units) below the measured number; measured number inside the range.
By their numbers in this assay, from the lowest: compounds 3, 1 and 4 (each within the scatter of the next, the first and the last beyond it); then compound 2.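

In this assay a ring now sits on the amine nitrogen, and the numbers show that this position accepts it: cyclopentyl in place of isobutyl gives a step that cannot be told apart from no change (the step is a 1.5-fold higher number from compound 1 to compound 4 (0.16 log units; within the scatter)), while cyclopentyl in place of heptyl gives a modest step (the step is a 2.3-fold higher number from compound 3 to compound 4 (0.37 log units; beyond the scatter)), so the ring and the long open chain can be separated even though isobutyl and heptyl could not. Compound 2, the only one of the four with two carbon groups on that nitrogen, also stays apart from the ring compound (cyclopentylamino in place of diethylamino gives a 2.2-fold lower number from compound 2 to compound 4 (0.35 log units; beyond the scatter)), which shows that a ring of carbon atoms on this nitrogen does not carry the number as far up as diethylamino does. No measurement offered here explains any of these differences.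

The compounds shown leave open whether a larger ring such as cyclohexyl, or a ring holding an oxygen atom such as tetrahydropyranyl, would behave like cyclopentyl on this nitrogen. They also leave open whether a phenyl group or a chain ending in a hydroxyl group would fit here as well as heptyl does.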